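A few compounds are considered here, and "the series" means these few. Any claim that something is new, unique, unknown or untested is made for them only; others in the source may bear on it.

Compound 1 `CCOC(=O)C1=Cc2ccccc2OC1(OCc1cn(CC(=O)Nc2ccc(C)cc2)nn1)C(F)(F)F` was tested in a functional assay on DU-145 cells (Homo sapiens) for inhibition, read by MTT assay, with a stated time of 24 h; on this read-out higher numbers stand for weaker inhibition and lower numbers for stronger inhibition. In this assay compound 1 gives only a limit, > 150000 nM, and no number. Compound 2 `O=C(O)C1=Cc2ccccc2OC1(OCc1cc(-c2ccc(F)cc2F)no1)C(F)(F)F` likewise gives only a limit, > 150000 nM. Compound 3 `CCOC(=O)C1=Cc2ccccc2OC1(OCc1cc(-c2ccc(Cl)cc2)no1)C(F)(F)F` gives an actual number, 18200 nM. Compound 1 thus stands at the limit of > 150000 nM in this assay, at which 2 of the 3 values shown sit, together with compound 2, while compound 3 alone has a measured value, so no comparison of size between them can be drawn. Compound 4 `CCOC(=O)C1=Cc2ccccc2OC1(OCc1cn(CC(=O)Nc2ccc(OC)cc2)nn1)C(F)(F)F` differs from compound 1 in one small change, (methoxy in place of methyl on an aromatic carbon). Going by the values given here, no measured pair of compounds shows this change, so its effect cannot be read from the data. The step from compound 1 to compound 4 is expected to be none beyond the scatter, a step that the limit leaves unreadable from compound 1 to compound 4. Compound 4 is therefore expected to give about 200000 nM, within 60000 nM to 700000 nM, most likely again reported only as a limit.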

Compound 4, half-maximal inhibitory concentration: 32700 nM
Compound 4: the middle estimate sits 6.1-fold (0.79 log units) above what was measured; measured number outside the range, below it.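

Placing methoxy in place of methyl on this aromatic ring is not a silent change: in this assay it gives an at least 4.5-fold lower number from compound 1 to compound 4 (0.66 log units; beyond the scatter), which means stronger inhibition. This position on the ring can therefore alter the read-out, at least in this one pair. The full size of the step stays unknown, since compound 1 gives a limit and not a number: the limit of > 150000 nM in this assay, at which 2 of the 4 values shown sit.

From the compounds shown here alone, it remains open how an amine, a hydroxyl or a longer chain at this position would behave. Going by these compounds, whether the same change would act alike on another compound also remains open.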